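The source may hold more compounds than are shown below. What is called first, only, known or untested is meant among the compounds shown, and "the series" means these compounds.

Of the compounds shown here, two with a shared core have been tested in an ADME assay on microsomes from liver (Mus musculus) for metabolic stability, read by LC-MS, with NADPH named in the record, with a stated time of 60 min, tested at 1 uM, in the absence of a further agent; on this read-out lower numbers stand for a less stable compound and higher numbers for a more stable compound. Compound 1, `CC(=O)N[C@@H]1CCN(c2cc(C)nn3c(-c4ccc(OC(F)(F)F)cc4)c(C)nc23)C1`, carries an acetamido group on its saturated ring. In this assay compound 1 gives > 95%, which is a limit of the assay rather than a number. Compound 2, `COc1ccc(-c2c(C)nc3c(N4CC[C@@H](NC(=O)Nc5ccccc5)C4)cc(C)nn23)cc1OC`, carries a (phenylcarbamoyl)amino group in the same place. In this assay compound 2 gives > 95%, again a limit rather than a number. Both values therefore sit at the limit of > 95% in this assay, at which 2 of the 2 values shown sit, so nothing separates them on the numbers shown.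

Compound 3, `COc1ccc(-c2c(C)nc3c(N4CCCC4)cc(C)nn23)cc1OC`, is the compound not yet measured. It differs from compound 2 by hydrogen in place of (phenylcarbamoyl)amino on a saturated ring carbon. Among the measured compounds shown here, no step between measured compounds is known here, so the size of this change can only be expected. The step from compound 2 to compound 3 is estimated at a number at least 15 percentage points lower from compound 2 to compound 3 (beyond the scatter), a loss somewhat beyond the usual scatter. Compound 3 is expected to give 80%, within a range from 50% to 95%.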

Compound 3, percent of the compound remaining: > 95%
Compound 3 gave a limit, no number (the forecaster's own chance of this, stated with the estimate: 40%); middle value at least 15 percentage points away from the limit.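

In this assay compound 3 gives > 95%, a limit rather than a number. Among the compounds shown here, compound 2 also sits at a limit, so no step between compound 2 and compound 3 can be read. Whether any change on the saturated ring alters this read-out stays open: the limit of > 95% in this assay, at which 3 of the 3 values shown sit.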